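Swapping fluorines for hydrogens on the amine side chain

The source may hold more compounds than are shown below. What is called first, only, known or untested is meant among the compounds shown, and "the series" means these compounds.

Compound 3 `Cc1cc(C)c(-n2c(Cl)cn3c(CN(CCC(F)(F)F)Cc4ccccc4)c(C(F)(F)F)nc23)c(C)c1` carries a trifluoropropyl arm and a benzyl arm on the amine nitrogen of its side chain. In an assay on cells for displacement of a labelled ligand from corticotropin-releasing factor receptor 1 (Homo sapiens), with a stated time of 100 min (on this read-out higher numbers stand for weaker inhibition and lower numbers for stronger inhibition), compound 3 gives 43 nM, the highest number among the three measured compounds, while compound 1 `Cc1cc(C)c(-n2c(Cl)cn3c(CN(CCC(F)(F)F)CC4CC4)c(C(F)(F)F)nc23)c(C)c1` gives 16 nM and compound 2 `C=CCN(CCC)Cc1c(C(F)(F)F)nc2n(-c3c(C)cc(C)cc3C)c(Cl)cn12` gives 4.5 nM. The measured steps frame this: a 2.7-fold higher number from compound 1 to compound 3 (0.43 log units; beyond the scatter) and a 3.6-fold lower number from compound 1 to compound 2 (0.55 log units; beyond the scatter).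

Compound 4 `CCCN(Cc1ccccc1)Cc1c(C(F)(F)F)nc2n(-c3c(C)cc(C)cc3C)c(Cl)cn12` differs from compound 3 by a single change: methyl in place of trifluoromethyl on a saturated chain carbon, two bonds along the chain from an amine nitrogen. Within the data shown here, the only measured step that touches this change is a 3.6-fold lower number from compound 1 to compound 2 (0.55 log units; beyond the scatter), where the trifluoropropyl arm became a propyl arm while the other arm on the nitrogen also changed, so that step mixes two alterations and cannot be read as a clean guide. The step from compound 1 to compound 3 concerns the other arm and does not bear on this change.

On that basis a modest move toward a lower number is expected for compound 4 in this assay, with wide uncertainty, as a 2.2-fold lower number from compound 3 to compound 4 (0.33 log units; beyond the scatter). The estimated value for compound 4 is 20 nM, with a range from 6 nM to 65 nM.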

Compound 4, inhibition constant: 170 nM
For compound 4 the middle estimate is 8.5-fold (0.93 log units) below the measured one; the measured number lies above the stated range.
By their numbers in this assay, from the lowest: compound 2; then compound 1; then compound 3; then compound 4.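

Among these compounds, with the benzyl arm held fixed, the first clean reading of this change in this assay is a 4.0-fold higher number from compound 3 to compound 4 (0.60 log units; beyond the scatter) on going from the 3,3,3-trifluoropropyl arm to the propyl arm, so here the trifluoromethyl goes with the lower number. The low number of compound 2 therefore cannot be credited to the propyl arm alone, and with the propyl arm held fixed, the other arm on the nitrogen carries a large effect, seen as a 38-fold higher number from compound 2 to compound 4 (1.58 log units; beyond the scatter) on going from allyl to benzyl. The remaining comparison, an 11-fold higher number from compound 1 to compound 4 (1.03 log units; beyond the scatter) with both arms replaced, is also large but gives only the combined result and cannot separate the two arms.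

Nothing available here explains the direction of the fluorine effect. Still open, from the compounds shown here alone, is whether the same swap gives the same direction with a cyclopropylmethyl or allyl arm on the nitrogen, and how a nitrile or a hydroxyl group would compare in place of the trifluoromethyl.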